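The source may report more compounds than this note shows. Statements on the series, on what has been measured and on what is new or still open speak of the compounds shown alone.

Measured so far:
- compound 1 `O=C(N/N=C/c1ccc(Cl)cc1Cl)Nc1cccc2ccccc12`: 300 mg/kg in a functional assay on the whole organism (strain Swiss albino) with Mus musculus as the target, with a stated time of 0.5 h; on this read-out lower numbers stand for an effect already at smaller amounts and higher numbers for an effect only at larger amounts of compound
- compound 2 `COc1ccc(/C=N/NC(=O)Nc2cccc3ccccc23)cc1OC`: 100 mg/kg in this assay

Of these two numbers, compound 1 carries the higher one; compound 2 sits at a lower number, and that gap lies beyond the usual scatter. Compound 3 `O=C(N/N=C/c1ccc(Br)cc1)Nc1cccc2ccccc12` is not yet measured. It differs from compound 1 in one place: 4-bromophenyl in place of 2,4-dichlorophenyl on a carbon with a double bond to nitrogen. Among the measured compounds shown here, no measured pair shows a change of this kind, so the step from compound 1 to compound 3 is expected to be a 1.5-fold lower number from compound 1 to compound 3 (0.18 log units; within the scatter), a modest move toward a lower number that stays within the scatter. Compound 3 is therefore expected to give about 200 mg/kg in this assay, within 100 mg/kg to 300 mg/kg.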

Compound 3, minimum effective dose: 300 mg/kg
Compound 3: middle estimate off by 1.5-fold (0.18 log units), on the low side; the measured number falls inside the stated range.
By their numbers in this assay, from the lowest: compound 2; then compounds 1 and 3 (each within the scatter of the next).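

Replacing 2,4-dichlorophenyl with 4-bromophenyl on a carbon with a double bond to nitrogen gives no change at the digits printed from compound 1 to compound 3 (within the scatter) in this assay. Among the compounds shown here, this single pair offers the first direct reading at this position: here, a ring with two chlorine atoms and a ring with one bromine atom cannot be told apart. Nothing shown explains this result.

As far as these compounds go, whether the position stays this flat for very different groups remains open. A ring carrying an amine or a carboxylic acid could still shift the dose needed, and so could a longer chain.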